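A few compounds are considered here, and "the series" means these few. Any claim that something is new, unique, unknown or untested is made for them only; others in the source may bear on it.

Two compounds of the series have numbers in a functional assay on Right cardiac atrium for agonist activity at histamine H2 receptor (Cavia porcellus), with a stated time of 30 min, in the presence of a further agent that is not named here (a lower number here means that less compound is needed, a higher number that more compound is needed for the effect), so far. Compound 1 `Cc1nc(N)sc1CCCN/C(N)=N/C(=O)N[C@H](C)c1ccccc1` gives 7.59 nM, and compound 2 `CCCCCNC(=O)/N=C(\N)NCCCc1sc(N)nc1C` gives 5.75 nM, the lowest of the two, with a 1.3-fold lower number from compound 1 to compound 2 (0.12 log units; within the scatter). Compound 3 `Cc1nc(N)sc1CCCN/C(N)=N/C(=O)NC(C)c1ccco1` differs from compound 2 by 1-(furan-2-yl)ethyl in place of pentyl on an amide-type nitrogen. Within the data shown here, the only step that bears on it, the pentyl-for-1-phenylethyl exchange, lay within the scatter, so no step beyond the scatter is expected in this assay. For compound 3 the estimate is 7 nM, between 3.5 nM and 14 nM, which is expected to mean a 1.2-fold higher number from compound 2 to compound 3 (0.09 log units; within the scatter).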

Compound 3, half-maximal effective concentration: 9.77 nM
Beside the measured number, compound 3's estimate is 1.4-fold (0.14 log units) below it; low and high end bracket the measured number.
By their numbers in this assay, from the lowest: compounds 2, 1 and 3 (each within the scatter of the next).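

In (this assay), 1-(furan-2-yl)ethyl on the amide-type nitrogen gives (a 1.7-fold higher number from compound 2 to compound 3 (0.23 log units; within the scatter)) and (a 1.3-fold higher number from compound 1 to compound 3 (0.11 log units; within the scatter)). This position therefore accepts a five-membered aromatic ring with one hetero atom, as well as pentyl and 1-phenylethyl, with no step beyond the scatter among the three compounds. Nothing available explains these numbers.

From the compounds shown here alone, whether any group at this nitrogen gives a step beyond the scatter remains open. A longer chain such as decyl, or a chain ending in an amine or a carboxylic acid, would test this.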